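Methoxy added to the ketone-side aryl ring of compound 1

This account rests on a few compounds, and the source may have more. Where it says the series, first, only, none or still open, it means among the compounds named here.

Within the data shown here, compound 1 `COc1ccc(C(=O)/C=C/c2cc(-c3cc(OC)c(OC)c(OC)c3)n[nH]2)cc1OC` is the only member of the pair with a number in a functional assay on A549 cells (Homo sapiens) for inhibition, read by sulforhodamine B assay, with a stated time of 48 h; on this read-out lower numbers stand for higher toxicity in this test and higher numbers for lower toxicity in this test: compound 1 gives 15700 nM. Compound 2 `COc1cc(-c2cc(/C=C/C(=O)c3ccc(F)c(F)c3)[nH]n2)cc(OC)c1OC` returns only a limit in this assay, > 100000 nM, which is the limit of > 100000 nM in this assay, at which 1 of the 2 values shown sits. Among the measured compounds shown here, the single measured step, an at least 6.3-fold higher number from compound 1 to compound 2 (0.80 log units; beyond the scatter), shows that the ring on the carbonyl carbon matters for this read-out, though the step is open at its upper end and cannot be sized.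

Compound 3 `COc1cc(C(=O)/C=C/c2cc(-c3cc(OC)c(OC)c(OC)c3)n[nH]2)cc(OC)c1OC` differs from compound 1 by methoxy in place of hydrogen on an aromatic carbon. For the measured compounds named here, no measured step adds a methoxy group at such a place; the step from compound 1 to compound 2 swaps both methoxy groups for fluorines rather than adding a third, so it bears on compound 3 only indirectly, by showing the ring is not inert to substitution. The expected change in this assay is therefore a step of a 2.0-fold lower number from compound 1 to compound 3 (0.29 log units; within the scatter), small and close to the scatter, leaning toward a lower number. Compound 3 is estimated at 8000 nM in this assay, within 2500 nM to 30000 nM.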

Compound 3, concentration lethal to 50% of the cells: 59200 nM
The estimate for compound 3 lay 7.4-fold (0.87 log units) below the measured number; measured number above the stated range.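

In this assay, methoxy in place of hydrogen on this aromatic carbon, ortho to a methoxy group and meta to a large group, gives a 3.8-fold higher number from compound 1 to compound 3 (0.58 log units; beyond the scatter), so the ring on the carbonyl carbon responds to the addition of a single group, and not only to the exchange of both methoxy groups for fluorines. Read together with an at least 6.3-fold higher number from compound 1 to compound 2 (0.80 log units; beyond the scatter), a step open at its upper end, both changes to this ring raise the number, which leaves compound 1 with the lowest number of the three and the highest toxicity in this test. Nothing measured here accounts for the rise seen with compound 3.

From the compounds shown here alone, whether the rise belongs to methoxy itself or would follow any group entering at this place stays open, and a hydroxy group, an amine or a chlorine on this aromatic carbon would bear on that question. Also open, going by these compounds, is whether the same methoxy addition would move the number in the same way on a ketone-side ring carrying fluorines, as in compound 2, whose only reading in this assay is a limit.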